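Methoxy for Fluoro on the Aryl of Compound 2

A few compounds are considered here, and "the series" means these few. Any claim that something is new, unique, unknown or untested is made for them only; others in the source may bear on it.

compound 1 `C=C(C)C(=O)c1ccc(OCc2nc(-c3ccc([N+](=O)[O-])cc3)no2)c(C)c1C` — 2300 nM
compound 2 `C=C(CC)C(=O)c1ccc(OCc2nc(-c3ccc(F)cc3)no2)c(Cl)c1Cl` — 3900 nM

Going by the values given here, in an assay on HL-60 cells for inhibition of glutathione S-transferase P (Homo sapiens) (on this read-out higher numbers stand for weaker inhibition and lower numbers for stronger inhibition), compound 2 gives 3900 nM, the highest of the two numbers measured so far. The nearest neighbour is compound 1, which gives 2300 nM; the gap between the two lies within the scatter, so no order between them can be stated. Compound 3 `C=C(CC)C(=O)c1ccc(OCc2nc(-c3ccc(OC)cc3)no2)c(Cl)c1Cl` differs from compound 2 in a single place: methoxy in place of fluoro on an aromatic carbon. Among the compounds with values here, no measured pair in this set shows such a swap, so there is no step to lean on. Without such a guide, the step from compound 2 to compound 3 is expected to be a 1.1-fold lower number from compound 2 to compound 3 (0.05 log units; within the scatter), a change estimated to stay within the scatter in either direction. Compound 3 is accordingly expected to give 3500 nM in this assay, with a range from 1200 nM to 10000 nM.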

Compound 3, half-maximal inhibitory concentration: 3800 nM
The estimate for compound 3 lay 1.1-fold (0.04 log units) below the measured number; low and high end bracket the measured number.
By their numbers in this assay, from the lowest: compounds 1, 3 and 2 (each within the scatter of the next).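

In this assay, going by these compounds alone, the change from 4-fluorophenyl to 4-methoxyphenyl gives a 1.0-fold lower number from compound 2 to compound 3 (0.01 log units; within the scatter) and is the first change in one place that can be read in this set. At this aromatic carbon, para to a large group, methoxy with its 2 heavy atoms and 1 hydrogen-bond acceptor thus takes the place of fluoro with no readable change in the number. Nothing at hand offers a reason for this result.

Compound 1 differs from compound 2 and compound 3 in more than one place, so its nitro group cannot be read against fluoro or methoxy. From the compounds shown here alone, whether an amine, a carboxylic acid or a longer alkoxy chain at the same carbon would move the number beyond the scatter remains open.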